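This account rests on a few compounds, and the source may have more. Where it says the series, first, only, none or still open, it means among the compounds named here.

Compound 1 `C#CCN(C)Cc1ccc[nH]1` is the reference point of this account. In an assay on mitochondria for inhibition of Amine oxidase [flavin-containing] B (Bos taurus), read by fluorescence (on this read-out lower numbers stand for stronger inhibition and higher numbers for weaker inhibition), compound 1 gives 20 nM, the lowest of the three numbers available. The two amide-bearing compounds that share its core lie far away: compound 2 `O=C(NCCCCc1ccccc1)c1ccc[nH]1` gives 57000 nM in this assay, and compound 3 `CC(NC(=O)c1ccc[nH]1)c1ccccc1` gives 61800 nM, both beyond the scatter from compound 1 by a wide margin. Nothing among these three compounds describes a change as small as the one now at hand, so no measured step can be drawn on for a direct comparison.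

Compound 4 `C#CCNCc1ccc[nH]1` differs from compound 1 by a single atom swap, hydrogen in place of methyl on an amine nitrogen. The propargyl group and the pyrrole-bearing core of compound 1 are kept intact. Within the data shown here, since the measured compounds offer no step of this kind, the size of the step must be judged from the change itself, and a moderate weakening in this assay is expected, one that exceeds the scatter but leaves compound 4 well clear of the amides. The step expected from compound 1 to compound 4 is a 5.0-fold higher number from compound 1 to compound 4 (0.70 log units; beyond the scatter). Compound 4 is thus expected to give 100 nM in this assay, within a range from 20 nM to 500 nM.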

Compound 4, inhibition constant: 620 nM
For compound 4 the middle estimate is 6.2-fold (0.79 log units) below the measured one; measured number above the stated range.
By their numbers in this assay, from the lowest: compound 1; then compound 4; then compounds 2 and 3 (each within the scatter of the next).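

Swapping the methyl for hydrogen on this amine nitrogen gives a 31-fold higher number from compound 1 to compound 4 (1.49 log units; beyond the scatter) in this assay, a large step beyond the scatter. The change is small in what is counted, since only one carbon leaves and the leaving methyl brings no ring, no hydrogen-bond donor or acceptor and no net charge, so this position proves highly sensitive to the loss of that single methyl. Among these compounds, this is the first step in the account that isolates one place in the structure, which the earlier compounds, differing from compound 1 in more than one place, could not do, and nothing available bears on why the step is this large.

The compounds shown compare only methyl and hydrogen on this nitrogen, leaving open how an ethyl group or a longer chain there would read in this assay, and whether any such group could match or pass the methyl. Also open, going by these compounds, is whether the step would keep its size with an allyl group in place of the propargyl group.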